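Removing the methylpiperazine from an anilino urea scaffold

The source may hold more compounds than are shown below. What is called first, only, known or untested is meant among the compounds shown, and "the series" means these compounds.

Compound 2 `C=CC(=O)N1CC[C@H](N2C(=O)N(c3ccccc3)Cc3cnc(Nc4ccc(N5CCN(C)CC5)cc4)nc32)C1` has the lower of the two numbers measured in an ADME assay on the whole organism (strain Sprague-Dawley) for pharmacokinetics, with Rattus norvegicus as the target, read by LC-MS, at a dose of 25 mg/kg by the oral route (a lower number here means slower removal, a higher number faster removal of the compound), where compound 2 gives 203 mL/min/kg; compound 1 `C=CC(=O)N1CC[C@H](N2C(=O)N(c3ccccc3)Cc3cnc(Nc4cccc(N5CCN(C)CC5)c4)nc32)C1` gives 565 mL/min/kg, a gap beyond the scatter. Compound 3 `C=CC(=O)N1CC[C@H](N2C(=O)N(c3ccccc3)Cc3cnc(Nc4ccccc4)nc32)C1` differs from compound 2 by hydrogen in place of 4-methylpiperazin-1-yl on an aromatic carbon. Among the measured compounds shown here, no measured pair shows this change, so its effect is unknown; the step from compound 2 to compound 3 in this assay is expected to stay within the scatter, a 1.2-fold higher number from compound 2 to compound 3 (0.09 log units; within the scatter). Compound 3 is therefore estimated at 250 mL/min/kg, between 80 mL/min/kg and 800 mL/min/kg.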

Compound 3, clearance: 95 mL/min/kg
Compound 3: middle estimate off by 2.6-fold (0.42 log units), on the high side, within the range that was stated.
By their numbers in this assay, from the lowest: compound 3; then compound 2; then compound 1.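

The step of a 2.1-fold lower number from compound 2 to compound 3 (0.33 log units; beyond the scatter) and the step of a 5.9-fold lower number from compound 1 to compound 3 (0.77 log units; beyond the scatter) come from the same change in this assay and go the same way, leaving compound 3 with the lowest number of the three. Compound 1 and compound 2 could only be compared with each other, but compound 3 now gives a reference without the 4-methylpiperazin-1-yl group, and both compounds carrying that group stand above it. Nothing shown explains this change in removal. The compounds leave open whether the whole group is needed for the higher numbers. A piperazine without its methyl, a morpholine ring or a methoxy group on that carbon could separate the contributions of its parts.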